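The source may report more compounds than this note shows. Statements on the series, on what has been measured and on what is new or still open speak of the compounds shown alone.

Within the data shown here, in a functional assay on SW-620 cells (Homo sapiens) for antiproliferative activity, read by MTT assay, with a stated time of 72 h (on this read-out higher numbers stand for weaker inhibition and lower numbers for stronger inhibition), compound 2 `O=C1O[C@H]([C@@H](O)Cn2cc(CNS(=O)(=O)c3ccc(F)cc3)nn2)C(OCc2ccccc2)=C1OCc1ccccc1` gives 41100 nM, and this is the only measured number in the set. Compound 1 `O=C1O/C(=C\Cn2cc(-c3cc(F)cc(F)c3)nn2)C(OCc2ccccc2)=C1OCc1ccccc1` reaches the limit of the assay in this assay, > 100000 nM, so no number stands for it. Compound 3 `O=C1O[C@H]([C@@H](O)Cn2cc(CCCCl)nn2)C(OCc2ccccc2)=C1OCc1ccccc1` differs from compound 2 in one place: 2-chloroethyl in place of ((4-fluorophenyl)sulfonyl)amino on a saturated chain carbon bound to an aromatic carbon. Among the measured compounds shown here, no step between two measured compounds is available to gauge such a change, so the expected step is modest, no larger than the scatter, a 1.2-fold higher number from compound 2 to compound 3 (0.09 log units; within the scatter). Compound 3 is therefore expected to give roughly 50000 nM, within a range from 15000 nM to 150000 nM.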

Compound 3, half-maximal inhibitory concentration: 68500 nM
For compound 3 the middle estimate is 1.4-fold (0.14 log units) below the measured one; the measured number falls inside the stated range.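

In this assay, among these compounds, the change of ((4-fluorophenyl)sulfonyl)amino to 2-chloroethyl on a saturated chain carbon bound to an aromatic carbon gives the first step at this position (a 1.7-fold higher number from compound 2 to compound 3 (0.22 log units; within the scatter)). The aromatic ring and the hydrogen-bond donor of the leaving group can thus go, with 11 heavy atoms giving way to 3, without a shift that stands out from the scatter. Among the compounds shown here, compound 1 gives no step, and its value is a limit: the limit of > 100000 nM in this assay, at which 1 of the 3 values shown sits.

As far as these compounds go, whether an amine, a carboxylic acid or a longer chain at this position would move the number beyond the scatter stays open. So does whether any group here brings markedly stronger inhibition.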